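A 4-chlorophenyl group replaces 3-methoxyphenyl on a shared core

This account rests on a few compounds, and the source may have more. Where it says the series, first, only, none or still open, it means among the compounds named here.

Of the compounds shown here, three built on one shared core have been measured in a functional assay on HeLa cells (Homo sapiens) for cytotoxicity, read by MTT assay, with a stated time of 48 h; on this read-out lower numbers stand for stronger inhibition and higher numbers for weaker inhibition. Compound 1 `C=C1CCC[C@]2(C)CCC(c3cn(-c4cccc([N+](=O)[O-])c4)nn3)=CC[C@@]12C` gives 31900 nM, compound 2 `C=C1CCC[C@]2(C)CCC(c3cn(-c4ccc(I)cc4)nn3)=CC[C@@]12C` gives 144000 nM, and compound 3 `C=C1CCC[C@]2(C)CCC(c3cn(-c4cccc(OC)c4)nn3)=CC[C@@]12C` gives 27900 nM. The data show a 1.1-fold lower number from compound 1 to compound 3 (0.06 log units; within the scatter), so these two sit level at the low end of the three numbers.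

Compound 4 `C=C1CCC[C@]2(C)CCC(c3cn(-c4ccc(Cl)cc4)nn3)=CC[C@@]12C` has not been measured yet. Its structure differs from that of compound 3 by one swap: 4-chlorophenyl in place of 3-methoxyphenyl on an aromatic nitrogen.

The most relevant measured change is a 5.2-fold lower number from compound 2 to compound 3 (0.71 log units; beyond the scatter). It links 3-methoxyphenyl with 4-iodophenyl, the closest match to the entering group, and read backwards it points towards a higher number. The change a 4.5-fold higher number from compound 1 to compound 2 (0.65 log units; beyond the scatter) points the same way. Among the measured compounds shown here, no measured compound carries 4-chlorophenyl itself, so only part of that modest shift is expected to carry over. In this assay, the expected change is a 2.2-fold higher number from compound 3 to compound 4 (0.33 log units; beyond the scatter), which could still prove hard to separate from the scatter. For compound 4 the estimated value is 60000 nM, with an expected range from 25000 nM to 140000 nM.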

Compound 4, half-maximal inhibitory concentration: 18800 nM
Estimate against measurement, compound 4: 3.2-fold (0.50 log units) above; measured number outside the range, below it.
By their numbers in this assay, from the lowest: compounds 4, 3 and 1 (each within the scatter of the next); then compound 2.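

In this assay the swap of one halogen alone gives a 7.7-fold lower number from compound 2 to compound 4 (0.88 log units; beyond the scatter) with chloro in place of iodo on an aromatic carbon, so the high number seen with 4-iodophenyl does not extend to 4-chlorophenyl. Both a 1.5-fold lower number from compound 3 to compound 4 (0.17 log units; within the scatter) and a 1.7-fold lower number from compound 1 to compound 4 (0.23 log units; within the scatter) lie within the scatter, so in this assay the groups 4-chlorophenyl, 3-methoxyphenyl and 3-nitrophenyl cannot be told apart, and compound 2 is the only one of the four that stands apart from the rest. Nothing measured here explains why the chloro and iodo compounds differ so clearly while the other three stay level.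

The compounds shown leave open whether 4-fluorophenyl or 4-bromophenyl would sit with 4-chlorophenyl or with 4-iodophenyl, so it remains unknown where along the halogens the number starts to rise. They also do not show whether a phenyl ring carrying an amine or a carboxylic acid would stay level with compound 3 and compound 4 or move away from them.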